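The compounds below may be only part of what the source reports. "The series", "measured", "known", "first", "only" and "open" are said of these compounds alone.

Three compounds share one core and were tested in an ADME assay on the whole organism (plasma, Macaca fascicularis) for protein binding, read by LC-MS, using equilibrium dialysis and cassette dosing, with a stated time of 24 h, at a dose of 1 mg/kg by the oral route; a higher number here means a larger unbound share of the compound, a lower number a smaller unbound share. Compound 2 `CCCCN(c1nc2c(C(=O)NC)cccc2o1)[C@H](C)c1ccc(-c2ccccc2-c2nnn[nH]2)cc1` stands highest: in this assay compound 2 gives 0.000975. Compound 3 `CCCCN(c1nc2c(C(=O)O)cccc2o1)[C@H](C)c1ccc(-c2cc(Cl)ccc2-c2nc(=O)o[nH]2)cc1` carries an acid in place of the amide of compound 2 and a chlorine on its biaryl, and in this assay compound 3 gives 0.000135, a gap to compound 2 that lies beyond the scatter. Compound 1 `C[C@H](c1ccc(-c2ccccc2-c2nc(=O)o[nH]2)cc1)N(CC1CC1)c1nc2c(C(=O)O)cccc2o1` combines an acid with a cyclopropylmethyl chain, and in this assay compound 1 gives 0.0000851, the smallest unbound share of the three, again beyond the scatter from compound 2.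

The new compound, compound 4 `CCCCN(c1nc2c(NC(C)=O)cccc2o1)[C@H](C)c1ccc(-c2ccccc2-c2nnn[nH]2)cc1`, differs from compound 2 in a single place: acetamido in place of methylcarbamoyl on an aromatic carbon. The two compounds hold the same atoms, joined differently, and the number of hydrogen-bond donors and acceptors is unchanged. Among the measured compounds shown here, no measured pair in this set isolates this swap, so the expectation rests on compound 2 alone and on the small nature of the change. The step expected from compound 2 to compound 4 in this assay is a 1.1-fold lower number from compound 2 to compound 4 (0.03 log units; within the scatter), that is, none beyond the scatter. Compound 4 is therefore estimated at 0.0009, with a range from 0.0004 to 0.002.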

Compound 4, unbound fraction: 0.00102
For compound 4 the middle estimate is 1.1-fold (0.05 log units) below the measured one; the measured number falls inside the stated range.
By their numbers in this assay, from the lowest: compounds 1 and 3 (each within the scatter of the next); then compounds 2 and 4 (each within the scatter of the next).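

Acetamido and methylcarbamoyl hold the same atoms joined differently, so the amide link runs the opposite way on this aromatic carbon, and in this assay the swap gives a 1.0-fold higher number from compound 2 to compound 4 (0.02 log units; within the scatter) and stays within the scatter. Among the compounds shown here, this is the first change in the set made in a single place, since compounds 1, 2 and 3 differ from one another in more than one place and could not separate the effect of this position from the others. It shows that, with the rest of compound 2 held fixed, the direction of the amide link at this position leaves the unbound share with no change beyond the scatter, and nothing available here explains why the two groups read alike.

Going by these compounds, whether other groups on this aromatic carbon, such as a primary amine, a nitrile or a sulfonamide, would also leave the unbound share where it stands remains open. So does whether acetamido and methylcarbamoyl would still read alike with another chain on the shared core, such as a hexyl chain in place of the butyl chain.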